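Side-chain change from compound 2 to compound 3

A few compounds are considered here, and "the series" means these few. Any claim that something is new, unique, unknown or untested is made for them only; others in the source may bear on it.

- compound 1 `O=C1c2c[n+]([O-])c3ccccc3c2C(=O)c2c1c1ccccc1n2Cc1cn(C[C@H](O)CO)nn1`: > 1000 nM
- compound 2 `CN1CCN(CCCCCCn2c3c(c4ccccc42)C(=O)c2c[n+]([O-])c4ccccc4c2C3=O)CC1`: 400 nM

Both entries come from a functional assay on MCF7 cells (Homo sapiens) for cytotoxicity, read by MTT assay, with a stated time of 72 h; a lower number here means a stronger inhibitor, a higher number a weaker inhibitor. The entry for compound 1 is a limit of the assay and not a number. In this assay, within the data shown here, compound 2 gives 400 nM, the only actual number so far.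

The next compound is compound 3 `CN1CCN(CCCCCn2c3c(c4ccccc42)C(=O)c2c[n+]([O-])c4ccccc4c2C3=O)CC1`, which has 4-methylpiperazin-1-yl in place of (4-methylpiperazin-1-yl)methyl on a saturated chain carbon, five bonds along the chain from an aromatic nitrogen.

Among the measured compounds shown here, only one measured step bears on this change, an at least 2.5-fold lower number from compound 1 to compound 2 (0.39 log units; beyond the scatter). That step replaces the whole group on the chain carbon and ends at compound 2, so it gives only loose guidance for a change that keeps the 4-methylpiperazin-1-yl group. As far as these compounds go, its size is also open-ended, as the limit of > 1000 nM in this assay, at which 1 of the 2 values shown sits, shows. No step beyond the scatter is therefore expected in this assay, and no direction is favoured.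

The expected step is a 1.1-fold higher number from compound 2 to compound 3 (0.05 log units; within the scatter). The estimate for compound 3 is 450 nM, with an expected range of 180 nM to 1100 nM.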

Compound 3, half-maximal inhibitory concentration: 1260 nM
The estimate for compound 3 lay 2.8-fold (0.45 log units) below the measured number; measured number above the stated range.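

In this assay, replacing (4-methylpiperazin-1-yl)methyl with 4-methylpiperazin-1-yl on the saturated chain carbon, five bonds along the chain from an aromatic nitrogen, gives a 3.2-fold higher number from compound 2 to compound 3 (0.50 log units; beyond the scatter), so the number responds to chain length even with the terminal 4-methylpiperazin-1-yl group held constant. The earlier readable step exchanged the whole group, leaving chain and terminal group entangled, whereas this pair separates them: the core and the terminal group are shared, and only 5-(4-methylpiperazin-1-yl)pentyl and 4-(4-methylpiperazin-1-yl)butyl differ. Compound 1 is recorded only as a limit, and the step from it to compound 3 cannot be read: the limit of > 1000 nM in this assay, at which 1 of the 3 values shown sits.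

As far as these compounds go, two chain lengths carrying one terminal group do not establish a trend, so it remains open whether a longer chain than 5-(4-methylpiperazin-1-yl)pentyl would lower the number further or raise it again. From the compounds shown here alone, it also remains open whether the 4-methylpiperazin-1-yl group is needed at the chain end, or whether a morpholine or a dimethylamino group on the same chain would give a similar number.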